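Swapping the chlorophenyl group on a sulfonyl-amide piperazine series

The compounds below may be only part of what the source reports. "The series", "measured", "known", "first", "only" and "open" are said of these compounds alone.

Measured compounds:
- compound 1, `O=C1c2ccccc2S(=O)(=O)N1CCCCCN1CCN(c2ccc(Cl)cc2)CC1`: 703 nM
- compound 2, `O=C1c2ccccc2S(=O)(=O)N1CCCCN1CCN(c2cccc(Cl)c2Cl)CC1`: 2660 nM
- compound 3, `COc1ccccc1N1CCN(CCCCCCN2C(=O)c3ccccc3S2(=O)=O)CC1`: 779 nM

All three compounds share a core and were tested in an assay on HEK293 cells for displacement of a labelled ligand from 5-hydroxytryptamine receptor 6 (Homo sapiens); a higher number here means a weaker inhibitor, a lower number a stronger inhibitor. Compound 1 has the lowest number of the three, but compound 3 sits so close to it that the two cannot be told apart within the usual scatter. Compound 2 stands clearly apart, with a number beyond the scatter from compound 1. Among the compounds with values here, no pair among the three differs in only one place, so none of these gaps can be pinned to a single structural change.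

Compound 4, `O=C1c2ccccc2S(=O)(=O)N1CCCCCN1CCN(c2cccc(Cl)c2Cl)CC1`, has not yet been measured. It differs from compound 1 in one place: 2,3-dichlorophenyl in place of 4-chlorophenyl on an amine nitrogen in a ring. The aryl group that enters is the same one carried by compound 2, whose number in this assay is the weakest of the three, although compound 2 also differs from compound 4 elsewhere.

Given this, compound 4 is expected to be somewhat weaker than compound 1, with an expected step of a 1.7-fold higher number from compound 1 to compound 4 (0.23 log units; within the scatter), though a result within the scatter would not be surprising. Compound 4 is estimated at 1200 nM, in a range from 400 nM to 3600 nM.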

Compound 4, inhibition constant: 197 nM
The estimate for compound 4 lay 6.1-fold (0.78 log units) above the measured number; the measured number lies below the stated range.
By their numbers in this assay, from the lowest: compound 4; then compounds 1 and 3 (each within the scatter of the next); then compound 2.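

In this assay, within the data shown here, 2,3-dichlorophenyl in place of 4-chlorophenyl on an amine nitrogen in a ring gives a 3.6-fold lower number from compound 1 to compound 4 (0.55 log units; beyond the scatter), a modest step but one beyond the scatter, so the pattern of chlorine on this aryl group matters to the number in a way the earlier compounds could not show. Compound 2 carries the same 2,3-dichlorophenyl group and gives 2660 nM, whereas compound 4 gives 197 nM, so this group does not by itself bring a low number, and the two compounds also differ elsewhere in their structures. Nothing available here explains why this swap lowers the number.

The step replaces one chlorine pattern with another and adds a chlorine, so the compounds shown cannot separate the two chlorines of the new group, and a single 2-chlorophenyl or 3-chlorophenyl group, or a plain phenyl group, would help to tell their contributions apart. On these data alone, it also remains open whether 2,3-dichlorophenyl gives a similar step when the core carries a longer chain.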